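A few compounds are considered here, and "the series" means these few. Any claim that something is new, unique, unknown or untested is made for them only; others in the source may bear on it.

Three compounds share one core and differ only in the group carried on one aromatic carbon. Compound 1 `CC(C)c1cnc(-c2nn(Cc3ccccc3F)c3ncccc23)nc1N` gives 207000 nM in a functional assay (aorta) with Oryctolagus cuniculus as the target; a lower number here means a stronger inhibitor, a higher number a weaker inhibitor. Compound 2 `Nc1nc(-c2nn(Cc3ccccc3F)c3ncccc23)ncc1C1CCCC1` gives 904000 nM in this assay, and compound 3 `CCCS(=O)(=O)c1cnc(-c2nn(Cc3ccccc3F)c3ncccc23)nc1N` gives 378000 nM in this assay. Among these numbers compound 3 stands second highest: the step of a 1.8-fold higher number from compound 1 to compound 3 (0.26 log units; within the scatter) lies within the scatter, while the step of a 2.4-fold lower number from compound 2 to compound 3 (0.38 log units; beyond the scatter) lies beyond it. Compound 4 `CC(C)S(=O)(=O)c1cnc(-c2nn(Cc3ccccc3F)c3ncccc23)nc1N` has the same atoms as compound 3, joined differently: isopropyl in place of propyl on a sulfonyl sulfur. For the measured compounds named here, none of the measured steps touches the sulfonyl sulfur; all of them, a 4.4-fold higher number from compound 1 to compound 2 (0.64 log units; beyond the scatter), a 1.8-fold higher number from compound 1 to compound 3 (0.26 log units; within the scatter) and a 2.4-fold lower number from compound 2 to compound 3 (0.38 log units; beyond the scatter), exchange whole groups on the aromatic carbon, and even so they reach at most modest size. A change confined to the shape of the propyl chain gives no ground to expect more, so for compound 4 no step beyond the scatter is expected in this assay, that is a 1.0-fold higher number from compound 3 to compound 4 (0.00 log units; within the scatter). The estimate for compound 4 is therefore 380000 nM, with an expected range from 150000 nM to 950000 nM.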

Compound 4, half-maximal inhibitory concentration: 517000 nM
Beside the measured number, compound 4's estimate is 1.4-fold (0.13 log units) below it; low and high end bracket the measured number.
By their numbers in this assay, from the lowest: compounds 1, 3, 4 and 2 (each within the scatter of the next, the first and the last beyond it).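

Isopropyl in place of propyl on the sulfonyl sulfur, the only step shown that touches this place, gives a 1.4-fold higher number from compound 3 to compound 4 (0.14 log units; within the scatter) in this assay, so the two shapes of this chain cannot be told apart here. With isopropylsulfonyl on the aromatic carbon, the exchange of whole groups gives a 1.7-fold lower number from compound 2 to compound 4 (0.24 log units; within the scatter) against cyclopentyl and a 2.5-fold higher number from compound 1 to compound 4 (0.40 log units; beyond the scatter) against isopropyl, and only the second of these steps lies beyond the scatter, at modest size. Nothing in the data gives a reason for these differences.

Still open, going by these compounds, is whether a longer chain such as butyl, or a ring such as phenyl, on the sulfonyl sulfur would shift the number beyond the scatter. Also open, on these data alone, is how an amine or a carboxylic acid on the aromatic carbon would compare with these groups.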